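The compounds below may be only part of what the source reports. "The series", "measured", "known", "first", "only" and "open" are said of these compounds alone.

In a functional assay on SK-N-SH cells (Homo sapiens) for cytotoxicity, read by MTT assay, with a stated time of 48 h (on this read-out higher numbers stand for weaker inhibition and lower numbers for stronger inhibition), compound 1 (`C=C(c1ccc(OC)cc1)c1cc(OC)c(OC)c(OC)c1-c1ccc(F)c(F)c1`) gives 7500 nM and compound 2 (`C=C(c1ccc(OC)cc1)c1cc(OC)c(OC)c(OC)c1-c1ccccc1`) gives 31000 nM as the highest of the two numbers. Compound 3 (`C=C(c1ccc(OC)cc1)c1cc(OC)c(OC)c(OC)c1-c1ccc(C(C)(C)C)cc1`) differs from compound 2 by tert-butyl in place of hydrogen on an aromatic carbon with tert-butyl in place of hydrogen on an aromatic carbon, para to a large group. Among the compounds with values here, one measured step bears on this phenyl, the modest 4.1-fold higher number from compound 1 to compound 2 (0.62 log units; beyond the scatter) when phenyl replaces 3,4-difluorophenyl. Within the data shown here, with only that guide, a modest move toward a lower number is expected in this assay and remains uncertain for this different group. The estimated change is a 1.9-fold lower number from compound 2 to compound 3 (0.29 log units; within the scatter) at most modestly sized. Compound 3 is expected at 16000 nM with an estimated range from 6000 nM to 45000 nM in this assay.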

Compound 3, half-maximal inhibitory concentration: 24000 nM
Beside the measured number, compound 3's estimate is 1.5-fold (0.18 log units) below it; the range from low to high includes it.
By their numbers in this assay, from the lowest: compound 1; then compounds 3 and 2 (each within the scatter of the next).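

In this assay, tert-butyl in place of hydrogen, para to a large group, gives a 1.3-fold lower number from compound 2 to compound 3 (0.11 log units; within the scatter), so this bulky substituent on the phenyl leaves the number within the scatter. The 3,4-difluorophenyl of compound 1 still stands apart, with a 3.2-fold higher number from compound 1 to compound 3 (0.51 log units; beyond the scatter), and tert-butyl does not reproduce that difference. No measurement shown here explains these numbers. The compounds shown leave open whether a single fluorine at this place on the ring, an amine or a carboxylic acid would shift the number as the 3,4-difluorophenyl does.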